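Triazole substituent changes on the shared core

The source may hold more compounds than are shown below. What is called first, only, known or untested is meant among the compounds shown, and "the series" means these compounds.

Compound 3 `CCCCCCCCCCc1cn(C[C@H](O)[C@H]2OC(=O)C(OCc3ccccc3)=C2OCc2ccccc2)nn1` gives 45200 nM in a functional assay on SW-620 cells (Homo sapiens) for antiproliferative activity, read by MTT assay, with a stated time of 72 h (a lower number here means a stronger inhibitor, a higher number a weaker inhibitor), the highest of the two numbers available. Compound 1 `O=C1O[C@H]([C@@H](O)Cn2cc(-c3ccc(Br)cc3)nn2)C(OCc2ccccc2)=C1OCc1ccccc1` gives 3760 nM in this assay, and the step between them is a 12-fold higher number from compound 1 to compound 3 (1.08 log units; beyond the scatter). Compound 2 `O=C1O[C@H]([C@@H](O)Cn2cc(-c3cccc(O)c3)nn2)C(OCc2ccccc2)=C1OCc1ccccc1` reaches only the assay limit of > 100000 nM in this assay. The related steps are an at least 26-fold higher number from compound 1 to compound 2 (1.42 log units; beyond the scatter) and an at least 2.2-fold lower number from compound 2 to compound 3 (0.34 log units; beyond the scatter).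

Compound 4 `O=C1O[C@H]([C@@H](O)Cn2cc(CNS(=O)(=O)c3ccc(Cl)cc3F)nn2)C(OCc2ccccc2)=C1OCc1ccccc1` is the next candidate: ((4-chloro-2-fluorophenyl)sulfonyl)amino in place of nonyl on a saturated chain carbon bound to an aromatic carbon. For the measured compounds named here, no measured step exchanges a chain for such a group; the nearest, a 12-fold higher number from compound 1 to compound 3 (1.08 log units; beyond the scatter), removed an aromatic ring and raised the number, while an at least 26-fold higher number from compound 1 to compound 2 (1.42 log units; beyond the scatter) shows a 3-hydroxyphenyl group raising it further. A modest lowering is therefore expected, with wide uncertainty. Compound 4 is expected to give 20000 nM, ranging from 5000 nM to 100000 nM. The expected step is a 2.3-fold lower number from compound 3 to compound 4 (0.35 log units; beyond the scatter).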

Compound 4, half-maximal inhibitory concentration: 42400 nM
Compound 4: middle estimate off by 2.1-fold (0.33 log units), on the low side; the measured number falls inside the stated range.
By their numbers in this assay, from the lowest: compound 1; then compounds 4 and 3 (each within the scatter of the next). At a limit, above all of these: compound 2.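

Exchanging nonyl for ((4-chloro-2-fluorophenyl)sulfonyl)amino on this saturated chain carbon gives no change beyond the scatter in this assay (a 1.1-fold lower number from compound 3 to compound 4 (0.03 log units; within the scatter)). An aromatic ring in the substituent therefore does not by itself bring the number down to that of compound 1 (3760 nM), and adding a hydrogen-bond donor and hydrogen-bond acceptors in place of the chain leaves it where it was. Nothing measured here accounts for this result. Still open, from the compounds shown here alone, is what an amine or a carboxylic acid at this place would give, and whether a shorter chain would behave as nonyl does.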